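Replacing a dimethylfluorophenyl amide with a thiazolyl amide

The source may hold more compounds than are shown below. What is called first, only, known or untested is meant among the compounds shown, and "the series" means these compounds.

Going by the values given here, compound 3 `COc1ccc2nc(C)cc(OCC(=O)Nc3cc(C)c(F)c(C)c3)c2c1` gives 31500 nM in a physicochemical assay for solubility, in phosphate buffer, measured as kinetic solubility, with a stated time of 1 h, at pH 7.4 (on this read-out higher numbers stand for higher solubility and lower numbers for lower solubility), the highest of the three numbers so far. Compound 2 `COc1ccc2nc(C)cc(OCC(=O)Nc3cc(C)c(OC)c(C)c3)c2c1` gives 17000 nM in this assay, and the step of a 1.9-fold higher number from compound 2 to compound 3 (0.27 log units; within the scatter) stays within the scatter. Compound 1 `CSc1ccc2nc(C)cc(OCC(=O)Nc3cc(C)cc(C)c3)c2c1` gives 3000 nM, and its gap to compound 3 lies beyond the scatter. Compound 4 `COc1ccc2nc(C)cc(OCC(=O)Nc3nccs3)c2c1` differs from compound 3 by 1,3-thiazol-2-yl in place of 4-fluoro-3,5-dimethylphenyl on an amide-type nitrogen. Among the compounds with values here, no measured step touches the group on the amide-type nitrogen, so the only measured step offers no direct guide. The entering group carries 2 hydrogen-bond acceptors where the leaving group carries none. Compound 4 is therefore expected to give about 60000 nM, in a range from 20000 nM to 180000 nM. That expectation amounts to a step of a 1.9-fold higher number from compound 3 to compound 4 (0.28 log units; within the scatter).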

Compound 4, solubility: 54000 nM
The estimate for compound 4 lay 1.1-fold (0.05 log units) above the measured number; low and high end bracket the measured number.
By their numbers in this assay, from the lowest: compound 1; then compounds 2, 3 and 4 (each within the scatter of the next, the first and the last beyond it).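

Going by these compounds alone, on the amide-type nitrogen, where no earlier step reached, the change to 1,3-thiazol-2-yl gives a 1.7-fold higher number from compound 3 to compound 4 (0.23 log units; within the scatter) in this assay. The carbon-only six-membered aromatic ring can thus give way to a five-membered aromatic ring with 2 hetero atoms, and the two numbers remain within the scatter of each other. Nothing measured here accounts for the step. Open, on these data alone, is how a pyridyl ring, or a thiazolyl ring carrying an amine or a carboxylic acid, would read on this nitrogen. Also open, as far as these compounds go, is whether the thiazolyl amide reads alike on a core with the methylthio group of compound 1.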